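A Chloro Group Added to Compound 3

The compounds below may be only part of what the source reports. "The series", "measured", "known", "first", "only" and "open" are said of these compounds alone.

In a functional assay on MV4-11 cells (Homo sapiens) for antiproliferative activity, read by CCK-8 assay, with a stated time of 72 h (on this read-out lower numbers stand for stronger inhibition and higher numbers for weaker inhibition), compound 3 (`Cn1cc(-c2ccccc2)c2cc(C(=O)NCc3ccc(C(=O)Nc4ccccc4N)cc3)[nH]c2c1=O`) gives 230 nM and stands level, within the scatter, with compound 2 (`COc1cccc(-c2cn(C)c(=O)c3[nH]c(C(=O)NCc4ccc(C(=O)Nc5ccccc5N)cc4)cc23)c1`) at 250 nM while compound 1 (`Cn1cc(-c2cccc(C(C)(C)O)c2)c2cc(C(=O)NCc3ccc(C(=O)Nc4ccccc4N)cc3)[nH]c2c1=O`) reads much higher (2200 nM). Compound 4 (`Cn1cc(-c2cccc(Cl)c2)c2cc(C(=O)NCc3ccc(C(=O)Nc4ccccc4N)cc3)[nH]c2c1=O`) differs from compound 3 by one change (chloro in place of hydrogen on an aromatic carbon): chloro in place of hydrogen on an aromatic carbon, meta to a large group. The nearest guide is hydrogen in place of methoxy on an aromatic carbon (a 1.1-fold lower number from compound 2 to compound 3 (0.04 log units; within the scatter)). The two modest steps both involve losing 1-hydroxy-1-methylethyl (an 8.8-fold lower number from compound 1 to compound 2 (0.94 log units; beyond the scatter)) and (a 9.6-fold lower number from compound 1 to compound 3 (0.98 log units; beyond the scatter)), a group absent here. The expected step is therefore small, an estimated 1.2-fold lower number from compound 3 to compound 4 (0.06 log units; within the scatter) with nothing beyond the scatter. Compound 4 is estimated at 200 nM with an expected range of 90 nM to 450 nM on this read-out.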

Compound 4, half-maximal inhibitory concentration: 190 nM
For compound 4 the middle estimate is 1.1-fold (0.02 log units) above the measured one; the range from low to high includes it.
By their numbers in this assay, from the lowest: compounds 4, 3 and 2 (each within the scatter of the next); then compound 1.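

In this assay, chloro on this aromatic carbon reads level with hydrogen (a 1.2-fold lower number from compound 3 to compound 4 (0.08 log units; within the scatter)) and with methoxy (a 1.3-fold lower number from compound 2 to compound 4 (0.12 log units; within the scatter)), so three small substituents now give numbers within the scatter of one another. Against chloro, 1-hydroxy-1-methylethyl remains the one group apart (a 12-fold lower number from compound 1 to compound 4 (1.06 log units; beyond the scatter)). Nothing measured here explains this difference.

On these data alone, whether an amine or a carboxylic acid at this place would stay level with these groups or read closer to compound 1 remains open. So does whether chloro would read the same on another carbon of this ring.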